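Furan in place of chlorophenyl on a nitrooxyacetamide chalcone

The source may report more compounds than this note shows. Statements on the series, on what has been measured and on what is new or still open speak of the compounds shown alone.

Measured so far:
Compound 1 `Nc1ccc(C(=O)/C=C/c2ccco2)cc1` gives 42%.
Compound 2 `O=C(CO[N+](=O)[O-])Nc1ccc(C(=O)/C=C/c2ccc(Cl)cc2)cc1` gives 69%.

In a functional assay on the whole organism (strain albino) for inhibition, with Rattus norvegicus as the target, read by paw edema, with stated times of 30 min and 3 h, at a dose of 100 mg/kg by the oral route (a higher number here means more inhibition at the dose given (going by the name of the read-out), a lower number less inhibition), compound 2 stands highest of the two numbers, and its nearest neighbour, compound 1, lies below it beyond the scatter. Compound 3 `O=C(CO[N+](=O)[O-])Nc1ccc(C(=O)/C=C/c2ccco2)cc1` differs from compound 2 by furan-2-yl in place of 4-chlorophenyl on a double-bonded chain carbon bound to a double-bonded chain carbon. Going by the values given here, no step between measured compounds that differ in one place is known, so the size of this change rests on nothing measured. Compound 1, which also carries the furan-2-yl group, is the lower of the two, so a modest decrease is expected from compound 2 to compound 3, as a number 11 percentage points lower from compound 2 to compound 3 (beyond the scatter). Compound 3 is estimated at 58%, within 45% to 72%.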

Compound 3, a percentage reported as inhibition, in the whole organism at one dose (the size of the read-out at that dose, not a potency): 48%
The estimate for compound 3 lay 10 percentage points above the measured number; the range from low to high includes it.
By their numbers in this assay, from the lowest: compounds 1 and 3 (each within the scatter of the next); then compound 2.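

In this assay, furan-2-yl in place of 4-chlorophenyl on a double-bonded chain carbon bound to a double-bonded chain carbon carries a real cost (a number 21 percentage points lower from compound 2 to compound 3 (beyond the scatter)), larger than the compounds known before could size. With furan-2-yl kept, ((nitrooxy)methyl)carbonyl in place of hydrogen on a nitrogen on an aromatic ring gives only a small step (a number 6 percentage points higher from compound 1 to compound 3 (within the scatter)), so here that group adds nothing beyond the scatter. No measurement on hand explains either step.

As far as these compounds go, whether that group would also stay without effect alongside 4-chlorophenyl remains open. So does how a thiophen-2-yl or 4-methoxyphenyl group would fare at this place.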